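The compounds below may be only part of what the source reports. "The series", "measured", "known", "first", "only" and "open" are said of these compounds alone.

Compound 1 `S=C(N/N=C/c1cccs1)Nc1ccccc1`: in a functional assay on PC-3 cells (Homo sapiens) for inhibition, read by sulforhodamine B assay, with a stated time of 48 h (a lower number here means a stronger inhibitor of growth, a higher number a weaker inhibitor of growth), compound 1 reaches > 100000 nM, which is a limit of the assay rather than a number.
Compound 2 `Cc1ccc(NC(=S)N/N=C/c2cccs2)cc1`: in this assay compound 2 gives 29700 nM.
Compound 3 `S=C(N/N=C/c1cccs1)Nc1cccnc1`: in this assay compound 3 reaches > 100000 nM, again a limit of the assay.

For the measured compounds named here, compound 1 therefore stands at the boundary of this assay, as the limit of > 100000 nM in this assay, at which 2 of the 3 values shown sit, shows; compound 2 is the one compound here with an actual number. The unmeasured compound 4 `S=C(N/N=C/c1cccs1)Nc1ccc(Br)cc1` differs from compound 1 by bromo in place of hydrogen on an aromatic carbon. Going by the values given here, the single measured step that bears on this change, a small group entering the same ring of compound 1, is an at least 3.3-fold lower number from compound 1 to compound 2 (0.52 log units; beyond the scatter). Bromo is not methyl, so that step is a guide and not a rule, and with compound 1 itself at a limit the starting point is uncertain. Compound 4 is nonetheless expected to move in the same direction, by about an at least 2.5-fold lower number from compound 1 to compound 4 (0.39 log units; beyond the scatter), to an estimated 40000 nM, with a range from 10000 nM to 150000 nM; a limit rather than a number remains a real possibility.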

Compound 4, concentration for 50% growth inhibition: 79400 nM
For compound 4 the middle estimate is 2.0-fold (0.30 log units) below the measured one, within the range that was stated.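

With compound 4, two groups can now be compared at the same place, para to a large group: in this assay the step is a 2.7-fold higher number from compound 2 to compound 4 (0.43 log units; beyond the scatter), so bromo and methyl are not interchangeable here. Bromo in place of hydrogen gives an at least 1.2-fold lower number from compound 1 to compound 4 (0.10 log units; that floor lies within the scatter), so the compounds do not show that bromo gives a real gain over hydrogen, even though compound 4 has an actual number. Only a floor can be read for that step, and the starting point remains uncertain: the limit of > 100000 nM in this assay, at which 2 of the 4 values shown sit.

From the compounds shown here alone, it remains open whether an amine, a methoxy group or a carboxylic acid at this place would give a number closer to that of compound 2. Going by these compounds, what bromo would do at another place on the ring also remains open.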